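Swapping 4-propylphenyl for 3-fluorophenyl on the shared core

A few compounds are considered here, and "the series" means these few. Any claim that something is new, unique, unknown or untested is made for them only; others in the source may bear on it.

In a functional assay on ECa-109 cells for inhibition, with ECa-109 cell line (Homo sapiens) as the target, read by sulforhodamine B assay (on this read-out higher numbers stand for weaker inhibition and lower numbers for stronger inhibition), compound 1 (`O=C1C(Nc2ccccc2)=CC(=O)c2c1nc1n2[C@H]2OC[C@@H](O)[C@H]2OC1`) reads 3560 nM as a measured number. Compound 2 (`O=C1C(N2CCC2)=CC(=O)c2c1nc1n2[C@H]2OC[C@@H](O)[C@H]2OC1`) reads > 16000 nM and this is a limit only. Compound 3 (`CCCc1ccc(NC2=CC(=O)c3c(nc4n3[C@H]3OC[C@@H](O)[C@H]3OC4)C2=O)cc1`) reads > 4000 nM and this too is a limit, so its standing in the series is not fixed by a number.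

Compound 4 (`O=C1C(Nc2cccc(F)c2)=CC(=O)c2c1nc1n2[C@H]2OC[C@@H](O)[C@H]2OC1`) carries 3-fluorophenyl in place of 4-propylphenyl on an amine nitrogen.

Among the compounds with values here, two measured steps bear on this change. The step of an at least 1.1-fold higher number from compound 1 to compound 3 (0.05 log units; that floor lies within the scatter) has a floor within the scatter and so settles little. The step of an at least 4.4-fold higher number from compound 1 to compound 2 (0.65 log units; beyond the scatter) lies beyond the scatter, but it removes the aromatic ring that compound 4 keeps. Compound 4 is therefore expected to read close to compound 1 at 3560 nM in this series.

The expected step is an at least 1.1-fold lower number from compound 3 to compound 4 (0.05 log units; that floor lies within the scatter) and no shift beyond the scatter is anticipated. For compound 4 the estimate is 3500 nM with an expected range from 1300 nM to 9000 nM in this assay as the working figure.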

Compound 4, half-maximal inhibitory concentration: 2370 nM
For compound 4 the middle estimate is 1.5-fold (0.17 log units) above the measured one, within the range that was stated.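

In this assay, the added fluoro group gives a 1.5-fold lower number from compound 1 to compound 4 (0.18 log units; within the scatter), so this substitution produces no shift that can be told from the scatter. (3-Fluorophenyl)amino in place of azetidin-1-yl on the double-bonded ring carbon gives an at least 6.7-fold lower number from compound 2 to compound 4 (0.82 log units; beyond the scatter), which clears the scatter, whereas 3-fluorophenyl in place of 4-propylphenyl on the amine nitrogen gives an at least 1.6-fold lower number from compound 3 to compound 4 (0.22 log units; that floor lies within the scatter), which does not. Both of these steps start from limits and not from numbers, one for compound 2 and one for compound 3.

From the compounds shown here alone, the true size of the step from compound 3 to compound 4 remains open. Also open, going by these compounds, is whether a chloro or methoxy group in place of the fluoro would move the read-out beyond the scatter from compound 1.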